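The compounds below may be only part of what the source reports. "The series", "measured", "known", "first", "only" and "open" are said of these compounds alone.

Measured so far in an assay on HEK293 cells for inhibition of Voltage-dependent N-type calcium channel subunit alpha-1B (Homo sapiens), read by patch clamp, using a membrane potential dye; a lower number here means a stronger inhibitor, a higher number a weaker inhibitor:
- compound 1, `COc1ccccc1-n1nc(C2CC(C)(C)OC(C)(C)C2)cc1-c1ccc(Cl)cc1`: 24 nM
- compound 2, `CCOc1ccc(-c2cc(C3CC(C)(C)OC(C)(C)C3)nn2-c2ccccc2OC)cn1`: 200 nM

Compound 2 holds the higher of these two numbers, which in this assay means the weaker inhibitor. Among the compounds with values here, its only comparison is compound 1, and the single measured step, an 8.3-fold higher number from compound 1 to compound 2 (0.92 log units; beyond the scatter), is the exchange of 4-chlorophenyl for 6-ethoxypyridin-3-yl on an aromatic carbon of the shared core.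

Compound 3, `COc1ccccc1-n1nc(C2CC(C)(C)OC(C)(C)C2)cc1-c1csc(Cl)c1`, is the next compound, and it differs from compound 2 by 5-chlorothiophen-3-yl in place of 6-ethoxypyridin-3-yl on an aromatic carbon. Within the data shown here, the one measured step bears on this change directly, because an 8.3-fold higher number from compound 1 to compound 2 (0.92 log units; beyond the scatter) moved away from a chlorine-bearing aromatic ring toward the ethoxypyridine and the number rose. The move to compound 3 brings a chlorine-bearing aromatic ring back, though a five-membered ring with sulfur rather than phenyl, so the number is expected to fall again by roughly a 4.4-fold lower number from compound 2 to compound 3 (0.65 log units; beyond the scatter), though perhaps not the whole way back. For compound 3 the expected value in this assay is 45 nM, with a likely range from 15 nM to 140 nM.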

Compound 3, half-maximal inhibitory concentration: 62 nM
Compound 3: middle estimate off by 1.4-fold (0.14 log units), on the low side, and the stated range covers the measured number.
By their numbers in this assay, from the lowest: compound 1; then compound 3; then compound 2.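

At this aromatic carbon of the shared core, in this assay, 5-chlorothiophen-3-yl gives a lower number than 6-ethoxypyridin-3-yl, with a 3.2-fold lower number from compound 2 to compound 3 (0.51 log units; beyond the scatter). This shows that a five-membered aromatic ring with sulfur is accepted here, and that among these three compounds, the two with a chlorine-bearing ring have lower numbers than the one with the ethoxypyridine. The thiophene does not fully match the 4-chlorophenyl group, however, since the change shows a 2.6-fold higher number from compound 1 to compound 3 (0.41 log units; beyond the scatter), and nothing available explains either difference.

The step from compound 2 to compound 3 changes the ring and its substituent together, so the compounds shown cannot tell how much of the difference comes from the ring and how much from chlorine in place of ethoxy. A 6-chloropyridin-3-yl group or an unsubstituted thiophen-3-yl group at this carbon would help pull those two parts apart.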